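Removing a methoxy from compound 3: what to expect

A few compounds are considered here, and "the series" means these few. Any claim that something is new, unique, unknown or untested is made for them only; others in the source may bear on it.

The three measured compounds share one core and differ only in the methoxy pattern on the far ring. In an ADME assay on RAW264.7 cells (Mus musculus) for cytotoxicity, read by MTT assay, with a stated time of 24 h, tested at 10 ug/mL (a higher number here means a weaker effect of the compound at the concentration tested, a lower number a stronger effect), compound 1 `COc1ccc(CCCc2ccc(OC)c(OC)c2)c(O)c1` gives 44.5%, compound 2 `COc1ccc(CCCc2ccc(OC)cc2OC)c(O)c1` gives 25.8%, and compound 3 `COc1ccc(CCCc2ccc(OC)c(OC)c2OC)c(O)c1` gives 36.7%. Compound 3 thus stands second highest of the three: its nearest neighbour is compound 1, which lies within the scatter, and its furthest is compound 2, which lies beyond it.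

Compound 4 `COc1ccc(CCCc2cccc(OC)c2OC)c(O)c1` is the next compound to be tested. The change from compound 3 is hydrogen in place of methoxy on an aromatic carbon, at an aromatic carbon ortho to one methoxy group, meta to another and para to the large group.

Among the compounds with values here, two measured steps bear on this, both in the opposite direction: adding a methoxy gave a number 7.8 percentage points lower from compound 1 to compound 3 (within the scatter) and a number 10.9 percentage points higher from compound 2 to compound 3 (beyond the scatter). So taking a methoxy away from this ring has moved the number either not at all or only modestly, with no fixed direction. Compound 4 is therefore expected to change little, a number 0.3 percentage points higher from compound 3 to compound 4 (within the scatter), staying within the scatter of compound 3. The estimate for compound 4 in this assay is 37%, within a range of 26% to 48%.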

Compound 4, a percentage reported as activity, at one concentration (the size of the read-out at that concentration, not a potency): 63%
Beside the measured number, compound 4's estimate is 26 percentage points below it; the whole stated range lies below it.
By their numbers in this assay, from the lowest: compound 2; then compounds 3 and 1 (each within the scatter of the next); then compound 4.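

Within the data shown here, compound 4 is the only one of the four compounds without a methoxy para to the large group, and replacing that methoxy with hydrogen gives a number 26.3 percentage points higher from compound 3 to compound 4 (beyond the scatter) in this assay and so marks a weaker effect at the concentration tested. The two earlier methoxy steps (a number 7.8 percentage points lower from compound 1 to compound 3 (within the scatter); a number 10.9 percentage points higher from compound 2 to compound 3 (beyond the scatter)) were made at other places on the same ring and were both smaller, so a single change at this place moves the number further than either of them did, and the methoxy groups on this ring do not count equally in this assay. Nothing measured here explains why this place weighs more than the others.

The compounds shown leave open whether the methoxy itself is needed at this place or whether another group there, such as an ethoxy, a fluorine or an amine, would hold the number near that of compound 3. They also leave open whether the size of this step holds when the methoxy ortho to this place or the one meta to it is absent, since compound 4 keeps both of these groups.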